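Swapping Chloro for Nitro on the Aryl Ring

The compounds below may be only part of what the source reports. "The series", "measured", "known", "first", "only" and "open" are said of these compounds alone.

Compound 1 `CN(C)c1ccc(N2C(=O)NC3(CSC4=C3C(=O)c3ncccc3C4=O)C2=O)cc1`: 90 nM
Compound 2 `COc1ccc(N2C(=O)NC3(CSC4=C3C(=O)c3ncccc3C4=O)C2=O)cc1`: 50 nM
Compound 3 `O=C1C2=C(C(=O)c3ncccc31)C1(CS2)NC(=O)N(c2ccc(Cl)cc2)C1=O`: 4 nM

All three compounds share one core and differ only in the group carried on an aromatic carbon of the phenyl ring. In a functional assay on ACHN cells (Homo sapiens) for antiproliferative activity, read by MTT assay, with a stated time of 96 h (a lower number here means a stronger inhibitor, a higher number a weaker inhibitor), the three numbers do not sit close together. The move a 1.8-fold lower number from compound 1 to compound 2 (0.26 log units; within the scatter) stays within the scatter, so compound 1 and compound 2 cannot be told apart. The moves a 23-fold lower number from compound 1 to compound 3 (1.35 log units; beyond the scatter) and a 13-fold lower number from compound 2 to compound 3 (1.10 log units; beyond the scatter) are both large and beyond the scatter, so compound 3 stands at the lowest number of the three and is the strongest inhibitor in this set.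

For the measured compounds named here, compound 4 `O=C1C2=C(C(=O)c3ncccc31)C1(CS2)NC(=O)N(c2ccc([N+](=O)[O-])cc2)C1=O` keeps the core of compound 3 and changes only one group: nitro in place of chloro on an aromatic carbon. Going by the values given here, no measured step involves nitro, so this change has no direct precedent among the three measured compounds. What the measured steps do show is that the group at this position can move the number by a large amount, as seen in the moves a 23-fold lower number from compound 1 to compound 3 (1.35 log units; beyond the scatter) and a 13-fold lower number from compound 2 to compound 3 (1.10 log units; beyond the scatter). With no guide for nitro itself, the expected step is a modest one, a 2.0-fold higher number from compound 3 to compound 4 (0.30 log units; within the scatter), and compound 4 is estimated at 8 nM, within a range from 2 nM to 40 nM.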

Compound 4, half-maximal inhibitory concentration: 100 nM
Compound 4: the middle estimate sits 13-fold (1.10 log units) below what was measured, outside the stated range (above it).
By their numbers in this assay, from the lowest: compound 3; then compounds 2, 1 and 4 (each within the scatter of the next).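

In this assay, the change from chloro to nitro is large, a 25-fold higher number from compound 3 to compound 4 (1.40 log units; beyond the scatter), so the low number of compound 3 is not shared by every group that can sit on this aromatic carbon. Compound 4 instead falls alongside the compounds carrying methoxy and dimethylamino, with a 2.0-fold higher number from compound 2 to compound 4 (0.30 log units; within the scatter) and a 1.1-fold higher number from compound 1 to compound 4 (0.05 log units; within the scatter), leaving these three unresolved from one another and chloro alone clearly apart from all of them. Nothing available here explains why chloro stands apart from the other three groups.

As far as these compounds go, how a fluoro or bromo group in place of the chloro would compare remains open, and these close relatives of chloro would show whether its low number extends to other halogens. From the compounds shown here alone, it is equally open whether a methyl group, a carboxylic acid or a longer chain at this position would give a number close to that of compound 3 or one in the range shared by the other three compounds.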